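The source may report more compounds than this note shows. Statements on the series, on what has been measured and on what is new or still open speak of the compounds shown alone.

Compound 1 `Oc1nc(-c2ccccc2F)nc2ccccc12`: 17.5 ug/mL
Compound 2 `COc1cc2nc(-c3ccccc3F)nc(O)c2cc1OC`: < 5 ug/mL

In a functional assay on KB cells (Homo sapiens) (on this read-out lower numbers stand for an effect already at smaller amounts and higher numbers for an effect only at larger amounts of compound), compound 2 gives < 5 ug/mL, which is a limit of the assay and not a number. Compound 3 `COc1cc2nc(-c3ccc(F)cc3)nc(O)c2cc1OC` carries 4-fluorophenyl in place of 2-fluorophenyl on an aromatic carbon. Among the compounds with values here, no measured pair shows this change, so no direction is favoured and no shift beyond the scatter is expected. The estimated step is a step that the limit leaves unreadable from compound 2 to compound 3. Compound 3 is expected at 4.5 ug/mL, with an estimated range of 1.5 ug/mL to 14 ug/mL.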

Compound 3, concentration for half-maximal effect: > 20 ug/mL
Compound 3 gave a limit, no number (the forecaster's own chance of this, stated with the estimate: 50%); at least 4.4-fold (0.64 log units) between middle value and limit.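

On the aromatic carbon between two ring nitrogen atoms, 4-fluorophenyl in place of 2-fluorophenyl gives in this assay an at least 4.0-fold higher number from compound 2 to compound 3 (0.60 log units; beyond the scatter), so with the same atoms joined differently, the place of the fluorine alone separates the two compounds. Compound 2 stands at a limit of the assay, not a number: the limit of < 5 ug/mL in this assay, at which 1 of the 3 values shown sits.
Compound 3 also stands at a limit of the assay, not a number: the limit of > 20 ug/mL in this assay, at which 1 of the 3 values shown sits.

As far as these compounds go, the true size of this step stays open. Also open, from the compounds shown here alone, is whether 3-fluorophenyl or 2-chlorophenyl on this carbon would track with compound 2 or with compound 3.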